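Replacing the cyclopropylcarbonyl with cyclopropylmethyl

A few compounds are considered here, and "the series" means these few. Any claim that something is new, unique, unknown or untested is made for them only; others in the source may bear on it.

The measured compounds and their numbers:
compound 1 `O=C(c1cc2ccccc2[nH]1)N1CCC(NCCSC(c2ccc(F)cc2)c2ccc(F)cc2)CC1`: 177 nM
compound 2 `Fc1ccc(C(SCCNC2CCN(Cc3cc4ccccc4o3)CC2)c2ccc(F)cc2)cc1`: 120 nM
compound 3 `O=C(C1CC1)N1CCC(NCCSC(c2ccc(F)cc2)c2ccc(F)cc2)CC1`: 178 nM

All three compounds share a core that carries two fluorophenyl groups and a six-membered ring bearing an amine nitrogen, and all three were tested in an assay on membranes from striatum (strain Sprague-Dawley) for displacement of a labelled ligand from sodium-dependent dopamine transporter (Rattus norvegicus), read by scintillation counting, with a stated time of 120 min; a lower number here means a stronger inhibitor, a higher number a weaker inhibitor. Compound 3 has the highest of the three numbers, but its nearest neighbour is compound 1 (a 1.0-fold higher number from compound 1 to compound 3 (0.00 log units; within the scatter)), and even compound 2 sits close (a 1.5-fold higher number from compound 2 to compound 3 (0.17 log units; within the scatter)). On these numbers the three compounds are not separated.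

Compound 4 `Fc1ccc(C(SCCNC2CCN(CC3CC3)CC2)c2ccc(F)cc2)cc1` has not yet been measured. It differs from compound 3 in one place: cyclopropylmethyl in place of cyclopropylcarbonyl on an amine nitrogen in a ring. The change removes the carbonyl and leaves a cyclopropylmethyl on the amine nitrogen in the ring.

For the measured compounds named here, two measured steps bear on this. The step from an indolylcarbonyl to a benzofuranylmethyl on the same nitrogen moved the number only slightly (a 1.5-fold lower number from compound 1 to compound 2 (0.17 log units; within the scatter)), and the step back from a methylene-linked to a carbonyl-linked group was equally small (a 1.5-fold higher number from compound 2 to compound 3 (0.17 log units; within the scatter)). Both are within the scatter, so no step beyond the scatter in this assay is expected for the change from compound 3 to compound 4, with at most a slight drift toward a lower number.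

Compound 4 is therefore expected to give about 130 nM, within a range from 50 nM to 350 nM, which means an expected step of a 1.4-fold lower number from compound 3 to compound 4 (0.14 log units; within the scatter).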

Compound 4, inhibition constant: 407 nM
The estimate for compound 4 lay 3.1-fold (0.50 log units) below the measured number; the measured number lies above the stated range.
By their numbers in this assay, from the lowest: compounds 2, 1 and 3 (each within the scatter of the next); then compound 4.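

In this assay, for the compounds shown here, exchanging cyclopropylcarbonyl for cyclopropylmethyl on the amine nitrogen in the ring gave a 2.3-fold higher number from compound 3 to compound 4 (0.36 log units; beyond the scatter), so, unlike the steps among the earlier compounds, this change at this position lies beyond the scatter. Compound 4 also stands apart from the other two, with a 3.4-fold higher number from compound 2 to compound 4 (0.53 log units; beyond the scatter) and a 2.3-fold higher number from compound 1 to compound 4 (0.36 log units; beyond the scatter), but the absence of a carbonyl does not by itself set it apart: compound 2 also has a methylene-linked group on this nitrogen, yet its number lies within the scatter of those of compound 1 and compound 3. Nothing available accounts for the higher number of compound 4.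

The compounds shown leave open whether the result follows from the cyclopropyl on the saturated chain carbon in particular or extends to other small groups there, a question that a cyclobutylmethyl, a cyclohexylmethyl or a plain ethyl on the same nitrogen would address. They also leave open how a phenylmethyl group or a carbonyl-linked group other than cyclopropylcarbonyl and (1H-indol-2-yl)carbonyl, such as acetyl, would compare at this position.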